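The compounds below may be only part of what the source reports. "The series", "measured", "known", "first", "only" and "open" are said of these compounds alone.

Compounds measured in a functional assay on PC-3 cells (Homo sapiens) for cytotoxicity; on this read-out higher numbers stand for an effect only at larger amounts of compound and lower numbers for an effect already at smaller amounts:
- compound 1 `COC1=C(C)C(=O)/C(=C(O)/C=C/c2ccc(Br)cc2)C(=O)C1(C)C` gives 17.7 ug/mL
- compound 2 `COC1=C(C)C(=O)/C(=C(O)/C=C/c2ccc(F)cc2)C(=O)C1(C)C` gives 7.2 ug/mL
- compound 3 `COC1=C(C)C(=O)/C(=C(O)/C=C/c2c(C)cccc2C)C(=O)C1(C)C` gives 17.1 ug/mL

Compound 3 stands at the upper end of these numbers, level with compound 1 and not with compound 2. The measured steps show a 1.0-fold lower number from compound 1 to compound 3 (0.01 log units; within the scatter), and also a 2.4-fold higher number from compound 2 to compound 3 (0.38 log units; beyond the scatter).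

The change now in question leads to compound 4 `COC1=C(C)C(=O)/C(=C(O)/C=C/c2nccs2)C(=O)C1(C)C` and puts 1,3-thiazol-2-yl in place of 2,6-dimethylphenyl on a double-bonded chain carbon bound to a double-bonded chain carbon. Among the compounds with values here, no measured compound carries this ring, so the evidence is indirect. The two steps above changed the same place, and the larger of them was only modest. A step of modest size or less is therefore expected in this assay, most likely within the scatter. Any lean is towards a lower number, since compound 3 already sits at the upper end with 17.1 ug/mL. The estimate amounts to a 1.4-fold lower number from compound 3 to compound 4 (0.15 log units; within the scatter). For compound 4 the expected value is 12 ug/mL, within an estimated range of 5.5 ug/mL to 26 ug/mL.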

Compound 4, concentration for half-maximal effect: 10.8 ug/mL
The estimate for compound 4 lay 1.1-fold (0.05 log units) above the measured number, and the stated range covers the measured number.
By their numbers in this assay, from the lowest: compounds 2, 4, 3 and 1 (each within the scatter of the next, the first and the last beyond it).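

In this assay, within the data shown here, the 1,3-thiazol-2-yl of compound 4 differs from the groups of the earlier compounds in being a five-membered aromatic ring with 2 hetero atoms rather than a six-membered ring of carbon only, yet replacing 2,6-dimethylphenyl gives only a 1.6-fold lower number from compound 3 to compound 4 (0.20 log units; within the scatter), within the scatter. Compound 4 also lies within the scatter of both fluorinated and brominated neighbours, with a 1.5-fold higher number from compound 2 to compound 4 (0.18 log units; within the scatter) and a 1.6-fold lower number from compound 1 to compound 4 (0.21 log units; within the scatter), although those two are separated by a 2.5-fold lower number from compound 1 to compound 2 (0.39 log units; beyond the scatter), so this place on the chain accepts a quite different ring with no step beyond the scatter. No measurement at hand accounts for this.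

The compounds shown leave open whether this place would keep such numbers with an amine, a carboxylic acid or a longer alkyl chain instead of an aromatic ring. They also leave open how much of the read-out comes from the shared core, which stays the same throughout.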